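Hydroxy to methyl on the ketone-bearing ring

The source may hold more compounds than are shown below. What is called first, only, known or untested is meant among the compounds shown, and "the series" means these compounds.

For the measured compounds named here, compound 2 `COC(=O)c1ccc(OCCCCOc2ccc(C(=O)CC(C)C)c(O)c2C)cc1` gives 22.7% in an assay on HEK293 cells for positive allosteric modulation of metabotropic glutamate receptor 3 (Rattus norvegicus), read by thallium flux, with a stated time of 2.5 min; on this read-out higher numbers stand for larger maximal responses and lower numbers for smaller maximal responses; this is the second highest of the three numbers measured so far. Compound 1 `Cc1c(OCCCCOc2ccc(C(=O)O)cc2)ccc(C(=O)CC(C)C)c1C` gives 16.6% in this assay, within the scatter of compound 2. Compound 3 `Cc1c(OCCCCOc2ccc(C(=O)O)c(Cl)c2)ccc(C(=O)CC(C)C)c1O` gives 49.5% in this assay, and the step of a number 26.8 percentage points higher from compound 2 to compound 3 (beyond the scatter) is beyond the scatter. Compound 4 `COC(=O)c1ccc(OCCCCOc2ccc(C(=O)CC(C)C)c(C)c2C)cc1` has not yet been measured. It differs from compound 2 by methyl in place of hydroxy on an aromatic carbon. Going by the values given here, the only measured step of a single change, a number 26.8 percentage points higher from compound 2 to compound 3 (beyond the scatter), alters the other end of the molecule and does not bear on this exchange. Among the compounds with values here, compound 1 and compound 2 differ in two places, one of them this same exchange; compound 1 gives 16.6% while compound 2 gives 22.7%, and these lie within the scatter of each other, which gives no basis for a step. No step beyond the scatter is therefore expected in this assay, and the step is estimated as a number 1.7 percentage points lower from compound 2 to compound 4 (within the scatter). Compound 4 is expected to give 21% in this assay, within a range from 8% to 36%.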

Compound 4, largest response reached (reported as percent of maximum), in percent of the reference or control that the assay uses: 27.3%
Compound 4: the middle estimate sits 6.3 percentage points below what was measured; the measured number falls inside the stated range.
By their numbers in this assay, from the lowest: compounds 1, 2 and 4 (each within the scatter of the next, the first and the last beyond it); then compound 3.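

In this assay, for the compounds shown here, methyl in place of hydroxy on this aromatic carbon, ortho to a methyl group and to an isobutylcarbonyl group, gives a number 4.6 percentage points higher from compound 2 to compound 4 (within the scatter) and so leaves the two compounds indistinguishable, which is the first single-change reading at this position. With this ring held constant, the methyl ester in place of the carboxylic acid gives a number 10.7 percentage points higher from compound 1 to compound 4 (beyond the scatter) and separates the pair, though only modestly. No measurement on these compounds accounts for either step.

From the compounds shown here alone, whether the hydroxy-to-methyl exchange reads the same in compounds carrying the carboxylic acid, with or without the chlorine on the other ring, remains open. Also open, going by these compounds, is how an amine or a methoxy group would read on this aromatic carbon.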